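Vinylcarbonyl for propanoyl on a diaryl urea pyrimidine ether

A few compounds are considered here, and "the series" means these few. Any claim that something is new, unique, unknown or untested is made for them only; others in the source may bear on it.

Measured compounds:
Compound 1, `Cc1ccc(NC(=O)Nc2ccc(Oc3cc(NCc4ccccc4)ncn3)cc2)cc1C(F)(F)F`, gives 3010 nM.
Compound 2, `CCC(=O)Nc1cc(Oc2ccc(NC(=O)Nc3ccc(C)c(C(F)(F)F)c3)cc2)ncn1`, gives 990 nM.

Both compounds were tested in a functional assay on BaF3 cells (Mus musculus) for inhibition, read by CCK-8 assay, with a stated time of 72 h; on this read-out lower numbers stand for stronger inhibition of growth and higher numbers for weaker inhibition of growth. Among the measured compounds shown here, compound 2 stands at the lower of the two numbers: the one step on record, a 3.0-fold lower number from compound 1 to compound 2 (0.48 log units; beyond the scatter), separates it from compound 1.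

Compound 3, `C=CC(=O)Nc1cc(Oc2ccc(NC(=O)Nc3ccc(C)c(C(F)(F)F)c3)cc2)ncn1`, is not yet measured. It differs from compound 2 in one place: vinyl in place of ethyl on a carbonyl carbon. For the measured compounds named here, no measured step bears directly on this change; the single step from compound 1 to compound 2 concerns the group on the aromatic nitrogen, not the chain on the carbonyl carbon. The vinyl and ethyl groups share the same heavy-atom count and neither carries a donor or acceptor, so nothing in the data argues for a large move in either direction.

For compound 3 the expectation is a number close to that of compound 2, with the step of a 1.7-fold lower number from compound 2 to compound 3 (0.22 log units; within the scatter) expected to stay within or only modestly beyond the scatter. The estimate for compound 3 is 600 nM, in the range 150 nM to 2500 nM.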

Compound 3, concentration for 50% growth inhibition: 1940 nM
Compound 3: middle estimate off by 3.2-fold (0.51 log units), on the low side; the range from low to high includes it.
By their numbers in this assay, from the lowest: compounds 2, 3 and 1 (each within the scatter of the next, the first and the last beyond it).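

In this assay the exchange of ethyl for vinyl on the carbonyl carbon gives a 2.0-fold higher number from compound 2 to compound 3 (0.29 log units; within the scatter), so the one double bond that vinyl adds does not separate compound 3 from compound 2 on this read-out. Compound 3 is not separated from compound 1 either, with a 1.6-fold lower number from compound 1 to compound 3 (0.19 log units; within the scatter), whereas propanoyl on the same nitrogen stood clearly apart from benzyl, with a 3.0-fold lower number from compound 1 to compound 2 (0.48 log units; beyond the scatter); the vinylcarbonyl group therefore sits within the scatter of both neighbours and does not repeat that clear distance. Nothing on hand offers an explanation for these values.

The compounds shown leave open whether a longer chain on the carbonyl carbon, a cyclopropyl group in place of ethyl, or a dimethylamino group carried on the end of the vinyl would move the number beyond the scatter from compound 2. They also leave open whether a free amine in place of the amide on the aromatic ring would fall with compound 1 or with compound 2.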